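Swapping methoxy for hydroxy in compound 1

This account rests on a few compounds, and the source may have more. Where it says the series, first, only, none or still open, it means among the compounds named here.

Measured so far in a functional assay on HCT-116 cells (Homo sapiens) for inhibition, with a stated time of 72 h (a higher number here means a weaker inhibitor, a lower number a stronger inhibitor), are two compounds
compound 1 `COc1ccccc1-c1ccc(CNc2nc(NC3CCC(N)CC3)nc3c2ncn3C2CCCC2)cc1` gives 430 nM
compound 2 `NC1CCC(Nc2nc(NCc3ccc(-c4ccccc4)nc3)c3ncn(C4CCCC4)c3n2)CC1` gives 563 nM

These two values lie within the usual scatter of repeated measurements, so compound 1 stands level with compound 2 and neither can be ranked above the other.

Compound 3 `NC1CCC(Nc2nc(NCc3ccc(-c4ccccc4O)cc3)c3ncn(C4CCCC4)c3n2)CC1` keeps the core of compound 1 and alters one place. The 2-methoxyphenyl becomes 2-hydroxyphenyl, with hydrogen in place of methyl on an oxygen on an aromatic ring. Within the data shown here, no measured pair shows this change, so the data give no direct guide to its size in this assay. The expectation therefore starts from compound 1 at 430 nM and foresees no clear move in either direction beyond the scatter. The estimated step (a 1.0-fold higher number from compound 1 to compound 3 (0.02 log units; within the scatter)) is accordingly small. The estimate for compound 3 is 450 nM (expected range 150 nM to 1300 nM).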

Compound 3, half-maximal inhibitory concentration: 4350 nM
The estimate for compound 3 lay 9.7-fold (0.99 log units) below the measured number; the measured number lies above the stated range.
By their numbers in this assay, from the lowest: compounds 1 and 2 (each within the scatter of the next); then compound 3.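

Going from 2-methoxyphenyl to 2-hydroxyphenyl gives a 10-fold higher number from compound 1 to compound 3 (1.01 log units; beyond the scatter) in this assay, so the group on this oxygen is far from a neutral detail: a single methyl, just one carbon atom, separates the two results. Among these compounds, the earlier compounds offered no step between measured compounds that differ in one place, so this is the first direct sign that a small edit to this part of the structure can strongly weaken inhibition. Nothing available explains why removing this methyl has so large an effect.

Still open, from the compounds shown here alone, is whether the effect depends on the size of the group on this oxygen, which an ethoxy or a longer alkoxy chain in the same place would test. It is also unclear how an amine or a fluorine in place of the methoxy would compare.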